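Swapping methyl for methoxy on the anilide ring

The source may hold more compounds than are shown below. What is called first, only, known or untested is meant among the compounds shown, and "the series" means these compounds.

Compound 3 `Cc1ccccc1NC(=O)CCC(=O)OCCCCCCSc1ccc([N+](=O)[O-])c2nonc12` is the (2-methylphenyl)amide of a small series whose other members are the free acid, compound 1 `O=C(O)CCC(=O)OCCCCCCSc1ccc([N+](=O)[O-])c2nonc12`, and the (2-chlorophenyl)amide, compound 2 `O=C(CCC(=O)OCCCCCCSc1ccc([N+](=O)[O-])c2nonc12)Nc1ccccc1Cl`. In a functional assay on 143B cells (Homo sapiens) for inhibition, read by MTT assay, with a stated time of 72 h (a higher number here means a weaker inhibitor, a lower number a stronger inhibitor), compound 1 gives 2830 nM, compound 2 gives 2430 nM, and compound 3 gives 4660 nM. Compound 3 carries the highest of the three numbers, but its separation from the others is small: a 1.6-fold higher number from compound 1 to compound 3 (0.22 log units; within the scatter) and a 1.9-fold higher number from compound 2 to compound 3 (0.28 log units; within the scatter), both within the scatter, as is a 1.2-fold lower number from compound 1 to compound 2 (0.07 log units; within the scatter). Compound 4 `COc1ccccc1NC(=O)CCC(=O)OCCCCCCSc1ccc([N+](=O)[O-])c2nonc12` differs from compound 3 in one place: methoxy in place of methyl on an aromatic carbon. The step that bears most directly on this change is a 1.9-fold higher number from compound 2 to compound 3 (0.28 log units; within the scatter), where one small group replaced another on an aromatic carbon and the number moved within the scatter only; the two steps from the acid, a 1.2-fold lower number from compound 1 to compound 2 (0.07 log units; within the scatter) and a 1.6-fold higher number from compound 1 to compound 3 (0.22 log units; within the scatter), show that the whole anilide portion is carried without a large effect. Nothing in these three compounds suggests that methoxy in place of methyl would behave differently, so the step expected in this assay is a 1.2-fold lower number from compound 3 to compound 4 (0.09 log units; within the scatter), nothing beyond the scatter. Compound 4 is therefore estimated at 3800 nM, with a range from 1500 nM to 9500 nM.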

Compound 4, half-maximal inhibitory concentration: 2120 nM
The estimate for compound 4 lay 1.8-fold (0.25 log units) above the measured number; low and high end bracket the measured number.
By their numbers in this assay, from the lowest: compounds 4, 2, 1 and 3 (each within the scatter of the next, the first and the last beyond it).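

In this assay, for the compounds shown here, the step of a 2.2-fold lower number from compound 3 to compound 4 (0.34 log units; beyond the scatter) is the first to pass beyond the scatter, though it is modest, so the group on this aromatic carbon, ortho to a large group, can shift the number slightly. Going by these compounds alone, the change does not set the methoxy anilide apart from the other two compounds it can be set against: a 1.1-fold lower number from compound 2 to compound 4 (0.06 log units; within the scatter) and a 1.3-fold lower number from compound 1 to compound 4 (0.13 log units; within the scatter) both stay within the scatter, so compound 4 cannot be told apart from either the chloro anilide or the free acid, and the only step here beyond the scatter is the one from the methyl anilide. No measurement shown here explains why methoxy and methyl differ on this carbon.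

On these data alone, it remains open whether a hydroxy or an amino group on this same carbon, or a methoxy group moved elsewhere on the ring, would stay within the scatter of compound 4. Within the data shown here, also open is whether the small step seen here would hold with a longer chain in place of the one these compounds share.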